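The compounds below may be only part of what the source reports. "The series", "measured", "known", "first", "only" and "open" are said of these compounds alone.

Compound 3 `O=C(C1CC1)N1CCc2nc(C#Cc3ccccc3)sc2C1` sits at the centre of this small set. Among the compounds with values here, in an assay on HEK293 cells for negative allosteric modulation of metabotropic glutamate receptor 5 (Homo sapiens), read by FLIPR, with a stated time of 1 h (on this read-out lower numbers stand for stronger inhibition and higher numbers for weaker inhibition), compound 3 gives 290 nM, and that is the only actual number among the three measured compounds. Compound 1 `O=C1NCCc2nc(C#Cc3ccccc3)sc21` reaches only a limit of the assay, reported as > 10000 nM. Compound 2 `CN1CCc2nc(C#Cc3cccc(F)c3)sc2C1` likewise stops at a limit, > 10000 nM. Two of the three readings therefore sit at the limit of > 10000 nM in this assay, at which 2 of the 3 values shown sit, and only compound 3, with a cyclopropyl carbonyl on its ring nitrogen, delivers a measurable value.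

The step to follow leads to compound 4 `Cc1cccc(C(=O)N2CCc3nc(C#Cc4ccccc4)sc3C2)n1`. The change is 6-methylpyridin-2-yl in place of cyclopropyl on a carbonyl carbon: the cyclopropyl leaves and a 6-methylpyridin-2-yl enters on the carbonyl carbon whose other neighbour is the amide-type nitrogen in the ring. Within the data shown here, no pair of measured compounds differs in a single place, so no measured step tells how large such a change is here.

The expectation is nonetheless a move towards stronger inhibition, estimated as a 5.8-fold lower number from compound 3 to compound 4 (0.76 log units; beyond the scatter) from compound 3 to compound 4 in this assay. Compound 4 is thus expected to show about 50 nM, within a range from 10 nM to 300 nM.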

Compound 4, half-maximal inhibitory concentration: > 10000 nM
Compound 4: only a limit was reported; the forecaster's own chance of this, stated with the estimate: 5%; middle value at least 200-fold (2.30 log units) from the limit.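

Within the data shown here, the one step in this set that can be read lies on the carbonyl carbon whose other neighbour is the amide-type nitrogen in the ring: in this assay, 6-methylpyridin-2-yl in place of cyclopropyl gives an at least 34-fold higher number from compound 3 to compound 4 (1.53 log units; beyond the scatter). The group at this place therefore matters greatly, and the carbonyl alone does not secure a measurable value, as compound 4 keeps both the carbonyl and the shared core. The reading for compound 4 is only a limit of the assay, and it joins the other compounds that stop there: the limit of > 10000 nM in this assay, at which 3 of the 4 values shown sit.

With a single change at this place, the compounds shown cannot separate the part played by the methyl from that of the pyridine ring. From the compounds shown here alone, how a plain phenyl, an unsubstituted pyridin-2-yl or a short chain such as ethyl would read on this carbonyl carbon also stays open.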